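From 1-phenylethyl to benzyl in a cytotoxicity test

A few compounds are considered here, and "the series" means these few. Any claim that something is new, unique, unknown or untested is made for them only; others in the source may bear on it.

Compound 1 `CCCNCc1c(C(=O)N2CCC(C(=O)NCCC)CC2)n(Cc2ccc(OC)cc2)c2ccsc12`: > 100000 nM (a limit)
Compound 2 `CCCNC(=O)C1CCN(C(=O)c2c(CNC(C)c3ccccc3)c3sccc3n2Cc2ccc(OC)cc2)CC1`: 57500 nM

Among the compounds with values here, in an ADME assay on HEK-293T cells (Homo sapiens) for cytotoxicity, read by luminescence, with a stated time of 24 h (on this read-out lower numbers stand for higher toxicity in this test and higher numbers for lower toxicity in this test), compound 2 gives 57500 nM, the only actual number so far.

Compound 1 gives > 100000 nM, which is a limit.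

Compound 3 `CCCNC(=O)C1CCN(C(=O)c2c(CNCc3ccccc3)c3sccc3n2Cc2ccc(OC)cc2)CC1` keeps the core of compound 2 and differs in one place: hydrogen in place of methyl on a saturated chain carbon bound to an amine nitrogen and an aromatic carbon. This is hydrogen in place of methyl on a saturated chain carbon bound to an amine nitrogen and an aromatic carbon, so 1-phenylethyl becomes benzyl.

Within the data shown here, the only measured step that bears on this concerns the same amine nitrogen: an at least 1.7-fold lower number from compound 1 to compound 2 (0.24 log units; that floor lies within the scatter). On that evidence, no step beyond the scatter is expected in this assay.

The expected step is a 1.1-fold higher number from compound 2 to compound 3 (0.05 log units; within the scatter).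

The estimate for compound 3 is 65000 nM, with an expected range of 30000 nM to 100000 nM.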

Compound 3, half-maximal cytotoxic concentration: 77600 nM
Compound 3: middle estimate off by 1.2-fold (0.08 log units), on the low side; low and high end bracket the measured number.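

In this assay, hydrogen in place of methyl on the saturated chain carbon gives a 1.3-fold higher number from compound 2 to compound 3 (0.13 log units; within the scatter), so removing this methyl produces no step beyond the scatter. Benzyl and propyl on the same amine nitrogen can now be compared as well, and that comparison gives an at least 1.2-fold lower number from compound 1 to compound 3 (0.11 log units; that floor lies within the scatter). The value of compound 1 is a limit and not a number, and this step is only a floor: the limit of > 100000 nM in this assay, at which 1 of the 3 values shown sits.

The compounds shown leave open whether a larger change on the amine nitrogen, such as a cyclohexylmethyl group or a chain ending in a carboxylic acid, would give a step beyond the scatter. They also leave open what a second methyl on the saturated chain carbon would do in this test.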